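From methoxy to chloropyridinyl on a shared core

The source may report more compounds than this note shows. Statements on the series, on what has been measured and on what is new or still open speak of the compounds shown alone.

Three measured compounds share one core. Compound 1 `C=CC(=O)Nc1cccc(Nc2ncnc(Nc3ccc(C(=O)N4CCCCC4)cc3)n2)c1` gives 6140 nM in a functional assay on Ramos cells (Homo sapiens) for antiproliferative activity, read by CCK-8 assay, with a stated time of 24 h; a higher number here means a weaker inhibitor, a lower number a stronger inhibitor. Compound 2 `C=CC(=O)Nc1cccc(Nc2ncnc(Nc3ccc(C(=O)Nc4ccccn4)cc3)n2)c1` carries a pyridinyl amide instead, and in this assay compound 2 has "not determined" (no result reported). Compound 3 `C=CC(=O)Nc1cccc(Nc2ncnc(Nc3ccc(OC)cc3)n2)c1` carries a methoxy group, and in this assay compound 3 gives 90000 nM, the highest of the two numbers at hand. Within the data shown here, the only step between measured compounds is a 15-fold higher number from compound 1 to compound 3 (1.17 log units; beyond the scatter), running from a group with a ring to the methoxy and ending at a much higher number.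

Compound 4 `C=CC(=O)Nc1cccc(Nc2ncnc(Nc3ccc(-c4ccc(Cl)nc4)cc3)n2)c1` differs from compound 3 by a single exchange: 6-chloropyridin-3-yl in place of methoxy on an aromatic carbon. Among the measured compounds shown here, no measured step exchanges a methoxy for an aromatic ring, so the one step that bears on it is a 15-fold higher number from compound 1 to compound 3 (1.17 log units; beyond the scatter), taken in reverse: the methoxy gives way to a group with a ring, and a downward move of similar size is expected. For compound 4 the expected step is a 15-fold lower number from compound 3 to compound 4 (1.18 log units; beyond the scatter). Compound 4 is therefore estimated at 6000 nM in this assay, within a range from 1200 nM to 30000 nM.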

Compound 4, half-maximal inhibitory concentration: 160000 nM
Estimate against measurement, compound 4: 27-fold (1.43 log units) below; measured number outside the range, above it.
By their numbers in this assay, from the lowest: compound 1; then compounds 3 and 4 (each within the scatter of the next).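

Putting 6-chloropyridin-3-yl in place of methoxy on this aromatic carbon gives no separable change in this assay, with a 1.8-fold higher number from compound 3 to compound 4 (0.25 log units; within the scatter). A six-membered aromatic ring at this position therefore does not reproduce the lower number of compound 1, as a 26-fold higher number from compound 1 to compound 4 (1.42 log units; beyond the scatter) shows, and among the measured compounds only the (piperidin-1-yl)carbonyl group stands apart from both methoxy and 6-chloropyridin-3-yl. No measurement at hand explains this difference.

The compounds shown leave open whether the carbonyl or the piperidine ring accounts for the lower number of compound 1, which a dimethylamide or a carboxylic acid at this position could help to separate. They also leave open whether a pyridin-3-yl group without the chlorine would fall with compound 3 and compound 4.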